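Two measured compounds and a third to estimate

The source may report more compounds than this note shows. Statements on the series, on what has been measured and on what is new or still open speak of the compounds shown alone.

Compound 1 `Cc1cc(Br)ccc1NC(=O)CN1CCC(c2cccc[n+]2[O-])CC1`: 61%
Compound 2 `Cc1cc(F)ccc1NC(=O)CN1CCC(c2cccc[n+]2[O-])CC1`: 84%

In a functional assay on HEK293 cells for agonist activity at D(4) dopamine receptor (Homo sapiens), read by FLIPR (a higher number here means a larger maximal response, a lower number a smaller maximal response), compound 2 gives 84%, the higher of the two values, while compound 1 gives 61%. Compound 3 `O=C(CN1CCC(c2cccc[n+]2[O-])CC1)Nc1cccc(Cl)c1` differs from compound 2 by 3-chlorophenyl in place of 4-fluoro-2-methylphenyl on an amide-type nitrogen. Among the measured compounds shown here, the single measured step, a number 23 percentage points higher from compound 1 to compound 2 (beyond the scatter), exchanged one halogen for another and nothing else, so it bears only in part on the present change, where the halogen changes again and the methyl group is lost as well. For the measured compounds named here, no measured step covers that combination. Compound 3 is therefore expected to land between the two known values, a step of a number 14 percentage points lower from compound 2 to compound 3 (beyond the scatter), with an estimate of 70% and a range from 45% to 95%.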

Compound 3, largest response reached (reported as efficacy), in percent of the reference or control that the assay uses: 76%
Estimate against measurement, compound 3: 6 percentage points below, and the stated range covers the measured number.
By their numbers in this assay, from the lowest: compound 1; then compounds 3 and 2 (each within the scatter of the next).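

In this assay, the exchange of 4-fluoro-2-methylphenyl for 3-chlorophenyl on the amide-type nitrogen gives a number 8 percentage points lower from compound 2 to compound 3 (within the scatter) and so removes the methyl group and changes the halogen without a step beyond the scatter. Against the bromo analogue, the same group gives a number 15 percentage points higher from compound 1 to compound 3 (beyond the scatter) and leaves compound 1 alone as the one set apart from both others. No available evidence accounts for these steps. The compounds shown leave open whether the loss of the methyl group and the change of halogen each matter alone or offset each other, and how a methoxy group or an amine on that phenyl ring would fare.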